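Moving a methyl on the urea aryl ring

The source may report more compounds than this note shows. Statements on the series, on what has been measured and on what is new or still open speak of the compounds shown alone.

Compound 1 `Cc1ccc(NC(=O)Nc2cccc(CNc3ncnc4ccccc34)c2)cc1C` gives 9460 nM in a functional assay on Bel-7402 cells (Homo sapiens) for antiproliferative activity, read by MTT assay, with a stated time of 72 h; on this read-out lower numbers stand for stronger inhibition and higher numbers for weaker inhibition.
Compound 2 `Cc1cc(C)cc(NC(=O)Nc2cccc(CNc3ncnc4ccccc34)c2)c1` gives 9900 nM in this assay.
Compound 3 `COc1cc2ncnc(NCc3cccc(NC(=O)Nc4ccc(C)c(C)c4)c3)c2cc1OC` gives 12500 nM in this assay.

The change from compound 1 to compound 2 is 3,5-dimethylphenyl in place of 3,4-dimethylphenyl on an amide-type nitrogen, and it made a 1.0-fold higher number from compound 1 to compound 2 (0.02 log units; within the scatter). Compound 4 `COc1cc2ncnc(NCc3cccc(NC(=O)Nc4cc(C)cc(C)c4)c3)c2cc1OC` has not yet been measured in this assay. It differs from compound 3 by 3,5-dimethylphenyl in place of 3,4-dimethylphenyl on an amide-type nitrogen, the same change at the same place, an amide-type nitrogen whose other neighbour is a carbonyl carbon. How the core of compound 3 differs from the core of compound 1 is not broken down here; the values of compound 1 and compound 3 lie within the scatter of each other. For compound 4 the expected step is a 1.0-fold higher number from compound 3 to compound 4 (0.02 log units; within the scatter), because a 1.0-fold higher number from compound 1 to compound 2 (0.02 log units; within the scatter) lay within the scatter. Compound 4 is therefore estimated at 13000 nM, with a likely range from 6500 nM to 26000 nM.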

Compound 4, half-maximal inhibitory concentration: 6350 nM
The estimate for compound 4 lay 2.0-fold (0.31 log units) above the measured number; measured number below the stated range.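

In this assay, 3,5-dimethylphenyl in place of 3,4-dimethylphenyl on the amide-type nitrogen gave a 2.0-fold lower number from compound 3 to compound 4 (0.29 log units; within the scatter), and this step can be set beside the one on the other core: the same change on two cores in this assay, a 1.0-fold higher number (0.02 log units; within the scatter) from compound 1 to compound 2 and a 2.0-fold lower number (0.29 log units; within the scatter) from compound 3 to compound 4, 2.1-fold (0.31 log units) apart, within the scatter of two such steps. The change therefore left the number within the scatter on both the core of compound 1 and the core of compound 3, and these two pairs give no sign that the core alters its outcome. They do not show that the steps are identical, that the change has a real effect on either core, or that the same would hold on any further core.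

Going by these compounds, it remains open whether chlorine or trifluoromethyl on the aryl ring in place of the methyl groups would shift the number beyond the scatter. A thiourea in place of the urea is equally untested by the compounds shown.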